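Dimethylpyridinyl swap from compound 3 to compound 4

The source may report more compounds than this note shows. Statements on the series, on what has been measured and on what is new or still open speak of the compounds shown alone.

In an in vitro ADME assay on microsomes from liver (Macaca fascicularis) for metabolic stability (a higher number here means faster removal of the compound, a lower number slower removal), compound 3 `CC[C@H](C)[C@@H]1C(=O)N[C@H](C2Cc3ccccc3C2)C(=O)N1[C@@H](C(=O)NC)c1cc(C)cnc1C` gives 5 mL.min-1.g-1, the lowest of the three numbers in hand. Compound 1 `CC[C@H](C)[C@@H]1C(=O)N[C@H](C2Cc3ccccc3C2)C(=O)N1[C@@H](C(=O)N1CCOCC1)c1cnc(C)cc1C` gives 16 mL.min-1.g-1 and compound 2 `CC[C@H](C)[C@@H]1C(=O)N[C@H](C2Cc3ccccc3C2)C(=O)N1[C@@H](C(=O)N(C)C)c1cnc(C)cc1C` gives 32 mL.min-1.g-1, and both lie beyond the scatter from compound 3.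

The change to compound 4 `CC[C@H](C)[C@@H]1C(=O)N[C@H](C2Cc3ccccc3C2)C(=O)N1[C@@H](C(=O)NC)c1cnc(C)cc1C` is 4,6-dimethylpyridin-3-yl in place of 2,5-dimethylpyridin-3-yl on a saturated chain carbon bound to an amide-type nitrogen in a ring and a carbonyl carbon. The two have the same atoms, joined differently.

For the measured compounds named here, no measured step isolates this exchange. The one available, a 2.0-fold higher number from compound 1 to compound 2 (0.30 log units; within the scatter), concerns the group on the carbonyl and stays within the scatter. Compound 4 shares its pyridinyl group with compound 1 and compound 2, and the group on its carbonyl with compound 3. Its number is therefore expected to fall among theirs, nearer the lower end, although the data cannot separate the contributions of the two sites. The estimated change is upward and moderate, a 2.4-fold higher number from compound 3 to compound 4 (0.38 log units; beyond the scatter), with wide uncertainty. For compound 4 the expected value in this assay is 12 mL.min-1.g-1, within an estimated range from 5 mL.min-1.g-1 to 28 mL.min-1.g-1.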

Compound 4, intrinsic clearance in microsomes: 20 mL.min-1.g-1
Estimate against measurement, compound 4: 1.7-fold (0.22 log units) below, and the stated range covers the measured number.
By their numbers in this assay, from the lowest: compound 3; then compounds 1, 4 and 2 (each within the scatter of the next).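

In this assay, the exchange of 2,5-dimethylpyridin-3-yl for 4,6-dimethylpyridin-3-yl on the saturated chain carbon is now isolated, with the methylamino group on the carbonyl unchanged, and it gives a 4.0-fold higher number from compound 3 to compound 4 (0.60 log units; beyond the scatter). For the compounds shown here, this is the first single-place step to lie beyond the scatter, whereas the steps at the carbonyl with 4,6-dimethylpyridin-3-yl held constant, a 1.6-fold lower number from compound 2 to compound 4 (0.20 log units; within the scatter) and a 1.3-fold higher number from compound 1 to compound 4 (0.10 log units; within the scatter), stay within it, so the arrangement of the same atoms in the pyridinyl group counts for more here than the choice among the three carbonyl substituents in these compounds. No supporting measurement accounts for the gap between the two pyridinyl isomers.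

Still open, from the compounds shown here alone, is whether 2,5-dimethylpyridin-3-yl gives the same gain when morpholin-4-yl or dimethylamino stands on the carbonyl carbon, as the low number of compound 3 rests on one pairing of the two sites. Also open, going by these compounds, is how a phenyl group, or a pyridin-3-yl carrying a single methyl, would read at the same saturated chain carbon.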